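This account rests on a few compounds, and the source may have more. Where it says the series, first, only, none or still open, it means among the compounds named here.

Measured so far:
- Compound 1 `Nc1ccccc1NC(=O)c1ccc(CSC(=S)N2CCc3ccccc32)cc1`: 3450 nM
- Compound 2 `Nc1ccccc1NC(=O)c1ccc(CSC(=S)N2CCc3cc(Cl)ccc32)cc1`: "not determined" (no result reported)

For the measured compounds named here, in a functional assay on HeLa cells (Homo sapiens) for antiproliferative activity, read by CCK-8 assay, with a stated time of 72 h (a higher number here means a weaker inhibitor, a lower number a stronger inhibitor), compound 1 gives 3450 nM, and this is the only number. Going by the values given here, compound 2 has no number in this assay, so it cannot be placed relative to compound 1, and no step between measured compounds is available.

The next structure is compound 3 `COC(=O)c1ccc2c(c1)CCN2C(=S)SCc1ccc(C(=O)Nc2ccccc2N)cc1`. Among the compounds with values here, it keeps the core of compound 2, and the one change is methoxycarbonyl in place of chloro on an aromatic carbon. The group sits on the same aromatic carbon, meta to a fused ring and para to a fused ring.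

Within the data shown here, with no measured step to draw on, neither the size nor the direction of this change can be read from the data. No shift beyond the usual scatter is expected in this assay relative to the single anchor, and the wide range reflects that thin basis. The expectation rests on compound 1 at 3450 nM.

For compound 3 the estimated value is 3500 nM, with an expected range of 1000 nM to 12000 nM.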

Compound 3, half-maximal inhibitory concentration: 3580 nM
For compound 3 the middle estimate is 1.0-fold (0.01 log units) below the measured one; measured number inside the range.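

In this assay, the aromatic carbon meta to a fused ring and para to a fused ring now has its first readable substitution: methoxycarbonyl in place of hydrogen gives a 1.0-fold higher number from compound 1 to compound 3 (0.02 log units; within the scatter). This carbon of the shared core therefore accepts a group of 4 heavy atoms, with 2 hydrogen-bond acceptors and a double bond outside the aromatic rings, with no shift beyond the scatter; the chloro-to-methoxycarbonyl step cannot be read, as compound 2 has no reported number. No accompanying data bear on this result, so it stands as an observation on a single pair of compounds.

As far as these compounds go, with only this one substitution readable, it remains open whether the flat result holds for groups of a different kind on the same aromatic carbon, such as an amine, a carboxylic acid or an ester with a longer chain. From the compounds shown here alone, it also remains open whether a group at this place can move the number beyond the scatter in either direction, since one step within the scatter fixes no trend for the series.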